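The source may report more compounds than this note shows. Statements on the series, on what has been measured and on what is new or still open speak of the compounds shown alone.

In a functional assay on Lewis lung carcinoma cells (Mus musculus) for antiproliferative activity, read by MTT assay, with a stated time of 24 h (on this read-out higher numbers stand for weaker inhibition and lower numbers for stronger inhibition), compound 1 (`C=CCc1cc(-c2cccc([N+](=O)[O-])c2)ccc1OC`) gives > 100000 nM as a limit of the assay, not a number. Compound 2 (`C=CCc1cc(-c2ccc(NC(C)=O)cc2)ccc1OC`) gives a true reading of 65100 nM in the same test. Compound 3 (`C=CCOc1ccc(-c2cccc([N+](=O)[O-])c2)cc1CC=C`) differs from compound 1 in one place (vinyl in place of hydrogen on a saturated chain carbon bound to an oxygen on an aromatic ring), which turns methoxy to allyloxy. Within the data shown here, no measured pair shows what such a change does, so only a small shift is expected, if any, towards stronger inhibition. The estimated step of an at least 1.1-fold lower number from compound 1 to compound 3 (0.04 log units; that floor lies within the scatter) is therefore modest, and compound 3 may also reach the limit. For compound 3 the estimated value is 90000 nM with an expected range from 40000 nM to 200000 nM in this assay when a number is obtained.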

Compound 3, half-maximal inhibitory concentration: > 100000 nM
Compound 3: only a limit was reported; the forecaster's own chance of this, stated with the estimate: 55%; at least 1.1-fold (0.04 log units) between middle value and limit.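

Compound 1 and compound 3 both stop at a limit, so no step can be read between them, because they share the same one: the limit of > 100000 nM in this assay, at which 2 of the 3 values shown sit.
In this assay, as far as these compounds go, the effect of going from methoxy to allyloxy stays open, with no number for either compound.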